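A few compounds are considered here, and "the series" means these few. Any claim that something is new, unique, unknown or untested is made for them only; others in the source may bear on it.

Measured so far:
compound 1, `CC1(C)[C@H]2CC[C@]1(C)N(Cc1cn(-c3ccccc3C#N)nn1)C(=O)C2`: 100 nM
compound 2, `CC1(C)[C@H]2CC[C@]1(C)N(Cc1cn(-c3ccccc3Cl)nn1)C(=O)C2`: 70 nM

Both compounds share one core and differ only in the group carried on an aromatic nitrogen. In a functional assay on A549 cells (Homo sapiens) for inhibition, read by MTT assay, with a stated time of 24 h (on this read-out higher numbers stand for weaker inhibition and lower numbers for stronger inhibition), compound 1 gives the highest of the two numbers, with compound 2 nearest, and the gap between them lies within the scatter. Going by the values given here, the single measured step, a 1.4-fold lower number from compound 1 to compound 2 (0.15 log units; within the scatter), shows that putting chloro in place of cyano on an aromatic carbon did not move the number beyond the scatter.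

Compound 3, `CC1(C)[C@H]2CC[C@]1(C)N(Cc1cn(-c3ccc(Cl)cc3)nn1)C(=O)C2`, has not been measured. It differs from compound 1 by 4-chlorophenyl in place of 2-cyanophenyl on an aromatic nitrogen. Among the compounds with values here, the step from compound 1 to compound 2 bears on this change in part, since it also brings in chloro on an aromatic carbon; no measured step shows what a different ring position of the chloro does, so the range is kept wider. Because a 1.4-fold lower number from compound 1 to compound 2 (0.15 log units; within the scatter) stayed within the scatter, the expected step is no change at the digits printed from compound 1 to compound 3 (within the scatter), nothing beyond the scatter. Compound 3 is therefore estimated at 100 nM, within 35 nM to 300 nM.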

Compound 3, half-maximal inhibitory concentration: 70 nM
The estimate for compound 3 lay 1.4-fold (0.15 log units) above the measured number; the measured number falls inside the stated range.
By their numbers in this assay, from the lowest: compounds 2, 3 and 1 (each within the scatter of the next).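

In this assay, the chloro group can sit on either of the two ring positions shown without the number leaving the scatter: 4-chlorophenyl in place of 2-chlorophenyl on the aromatic nitrogen gives no change at the digits printed from compound 2 to compound 3 (within the scatter). Going by these compounds alone, this is the first measured comparison of ring position for that group, which the earlier compounds could not provide. Exchanging 2-cyanophenyl for 4-chlorophenyl, which changes both the group and its ring position, gives a 1.4-fold lower number from compound 1 to compound 3 (0.15 log units; within the scatter), so this double change also stays within the scatter, and nothing shown explains these results.

All three compounds carry a phenyl ring with one chloro or nitrile group on the aromatic nitrogen. From the compounds shown here alone, what an amine or a carboxylic acid on that ring would do, or a longer chain in place of the ring, remains open.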